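A few compounds are considered here, and "the series" means these few. Any claim that something is new, unique, unknown or untested is made for them only; others in the source may bear on it.

Measured so far:
- compound 1 `O=C(O)c1cncc(C2=C(c3cc(Cl)ccc3OCc3ccc(F)cc3F)CCC2)n1` gives 2 nM in an assay on isolated protein for inhibition of prostaglandin E2 receptor EP1 subtype (Homo sapiens); on this read-out higher numbers stand for weaker inhibition and lower numbers for stronger inhibition
- compound 2 `CSc1ccc(OCc2ccc(F)cc2F)c(C2=C(c3cccc(C(=O)O)c3)CCC2)c1` gives 15.9 nM in this assay
- compound 3 `O=C(O)c1cc(C2=C(c3cc(Cl)ccc3OCc3ccccc3)CCC2)ncn1` gives 200 nM in this assay

Compound 3 has the highest number of the three. Against compound 2 the gap is beyond the scatter, and against compound 1 it is wider still, also beyond the scatter. No pair among these three differs in one place only, so none of the gaps can be attached to a single structural change.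

Compound 4 `O=C(O)c1ccnc(C2=C(c3cc(Cl)ccc3OCc3ccccc3)CCC2)n1` keeps every atom of compound 3 and differs only in how the acid-bearing ring is joined: 4-carboxypyrimidin-2-yl in place of 6-carboxypyrimidin-4-yl on a double-bonded ring carbon. Within the data shown here, no step between measured compounds shows what such a change does in this assay; compound 1 and compound 2 carry different acid-bearing rings and different benzyl groups at the same time, so they give no guide here.

The working expectation is a modest step toward a lower number, a 2.0-fold lower number from compound 3 to compound 4 (0.30 log units; within the scatter), with the direction itself uncertain. Compound 4 is accordingly estimated at 100 nM, within a range from 20 nM to 600 nM.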

Compound 4, half-maximal inhibitory concentration in the prostaglandin E2 receptor EP1 subtype assay: 158 nM
Estimate against measurement, compound 4: 1.6-fold (0.20 log units) below, within the range that was stated.
By their numbers in the prostaglandin E2 receptor EP1 subtype assay, from the lowest: compound 1; then compound 2; then compounds 4 and 3 (each within the scatter of the next).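

Replacing 6-carboxypyrimidin-4-yl with 4-carboxypyrimidin-2-yl on a double-bonded ring carbon gives, in the prostaglandin E2 receptor EP1 subtype assay, a 1.3-fold lower number from compound 3 to compound 4 (0.10 log units; within the scatter), so this rearrangement of the same atoms leaves that read-out within the scatter. In a physicochemical assay for lipophilicity (on this read-out higher numbers stand for higher lipophilicity and lower numbers for lower lipophilicity), compound 3 gives 1.2 and compound 4 gives 0.8. Among these compounds, in the physicochemical assay the pair does separate, with lower lipophilicity for compound 4 and no matching shift in the prostaglandin E2 receptor EP1 subtype assay: the measured distribution coefficient of compound 3, 1.2, and of compound 4, 0.8, a number 0.40 log units lower (beyond the scatter) The earlier compounds could not show this, as no two of them differed in one place.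

Every compound shown carries a carboxylic acid, and the effect of a tetrazole in its place on either read-out remains open. Also open, going by these compounds, is whether this change of ring joining stays as small when the benzyl group carries fluorine atoms, as in compound 1.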